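The source may hold more compounds than are shown below. What is called first, only, known or untested is meant among the compounds shown, and "the series" means these compounds.

Compound 2 `COc1ccn2c(-c3ccc(NC(=O)c4ccc([N+](=O)[O-])o4)cc3)cnc2c1` carries a methoxy on its shared core, and in a functional assay on AGS cells (Homo sapiens) for antiproliferative activity, read by CCK-8 assay, with a stated time of 72 h (on this read-out lower numbers stand for stronger inhibition and higher numbers for weaker inhibition), compound 2 gives 720 nM. Two other measured compounds frame it. Compound 1 `O=C(Nc1ccc(-c2cnc3cc(N4CCCC4)ccn23)cc1)c1ccc([N+](=O)[O-])o1` bears a pyrrolidin-1-yl where compound 2 has methoxy, and in this assay compound 1 gives 1240 nM. Compound 3 `COc1ccn2c(-c3ccc(NC(=O)c4ccc([N+](=O)[O-])o4)cc3F)cnc2c1` adds a fluoro to the amide-bearing phenyl ring, and in this assay compound 3 gives 700 nM. The number for compound 2 lies in the middle of the three, with compound 3 nearest and compound 1 furthest, but both gaps fall within the scatter: the change in a 1.7-fold lower number from compound 1 to compound 2 (0.24 log units; within the scatter) and that in a 1.0-fold lower number from compound 2 to compound 3 (0.01 log units; within the scatter) are each too small to read as real differences.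

Compound 4 `COc1ccn2c(-c3ccc(NC(=O)c4ccc([N+](=O)[O-])o4)c(OC)c3)cnc2c1` is compound 2 with a further substituent: methoxy in place of hydrogen on an aromatic carbon. Going by the values given here, the only measured step that speaks to substitution on this phenyl ring is the one from compound 2 to compound 3, which added a fluoro there and stayed within the scatter. Among the compounds with values here, no measured pair shows a methoxy added to this ring, so nothing argues for a movement beyond the scatter in either direction. Compound 4 is therefore expected to land near compound 2, with an estimated step of a 1.0-fold lower number from compound 2 to compound 4 (0.01 log units; within the scatter), and its expected value in this assay is 700 nM, in the range 350 nM to 1400 nM.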

Compound 4, half-maximal inhibitory concentration: 3880 nM
For compound 4 the middle estimate is 5.5-fold (0.74 log units) below the measured one; measured number above the stated range.
By their numbers in this assay, from the lowest: compounds 3, 2 and 1 (each within the scatter of the next); then compound 4.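

In this assay, going by these compounds alone, the phenyl ring that carries the amide responds to substitution for the first time (the step is a 5.4-fold higher number from compound 2 to compound 4 (0.73 log units; beyond the scatter)), whereas the only earlier change on this ring stayed inside the scatter (a 1.0-fold lower number from compound 2 to compound 3 (0.01 log units; within the scatter)). The loss therefore shows that this ring does not accept every added group equally, at least for a methoxy placed on an aromatic carbon ortho to a large group and meta to a large group. Nothing available here explains why this methoxy weakens the antiproliferative read-out, as no accompanying data bear on the result.

As far as these compounds go, whether the loss goes with the methoxy itself or with the carbon it occupies stays open, and a hydroxyl, a chloro or an amine at the same place would help to tell these apart. Also open, from the compounds shown here alone, is whether the same methoxy would give a step of similar size on the core of compound 1, which carries pyrrolidin-1-yl rather than methoxy.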